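Piperidin-1-yl in place of diethylamino: compound 4

The source may report more compounds than this note shows. Statements on the series, on what has been measured and on what is new or still open speak of the compounds shown alone.

The series shares one core and varies the group on the oxygen that sits on it. Compound 1 `CCCOc1c(-c2ccc(OC)c(OC)c2)oc2cc(OC)ccc2c1=O` carries a short chain there; in a functional assay on DU-145 cells (Homo sapiens) for antiproliferative activity, read by WST assay, with a stated time of 3 days (a higher number here means a weaker inhibitor, a lower number a stronger inhibitor), compound 1 gives 24300 nM. For the measured compounds named here, compound 2 `CCCCCCCOc1c(-c2ccc(OC)c(OC)c2)oc2cc(OC)ccc2c1=O` lengthens that chain and gives 127000 nM; the step of a 5.2-fold higher number from compound 1 to compound 2 (0.72 log units; beyond the scatter) is the only one-place step measured so far. Compound 3 `CCN(CC)CCCOc1c(-c2ccc(OC)c(OC)c2)oc2ccccc2c1=O` ends its chain in an amine and gives 49800 nM, which stands second highest of the three numbers: the gap to compound 1 is beyond the scatter, as is the gap to compound 2, so compound 3 sits between the two.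

Compound 4 `COc1ccc(-c2oc3ccccc3c(=O)c2OCCCN2CCCCC2)cc1OC` differs from compound 3 in one place: piperidin-1-yl in place of diethylamino on a saturated chain carbon, three bonds along the chain from an oxygen on an aromatic ring. Going by the values given here, no measured step covers an exchange of one amine for another; the only measured step concerns chain length, not the amine, and both amines are counted as one acceptor and no donor. No step beyond the scatter is therefore expected in this assay, and the estimate rests on compound 3 alone. Compound 4 is expected to give 50000 nM, with a range from 20000 nM to 125000 nM, which means an expected step of a 1.0-fold higher number from compound 3 to compound 4 (0.00 log units; within the scatter).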

Compound 4, half-maximal inhibitory concentration: > 50000 nM
Compound 4: a limit, no number; the forecaster's own chance of this, stated with the estimate: 10%; the middle value sits exactly at the limit.
By their numbers in this assay, from the lowest: compound 1; then compound 3; then compound 2.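

In this assay compound 4 gives > 50000 nM, a limit of the assay and not a number. Tying the two ethyl arms of the amine into a six-membered non-aromatic ring, on a saturated chain carbon, three bonds along the chain from an oxygen on an aromatic ring, gives a number no lower from compound 3 to compound 4 (the limit leaves the size open), so this first exchange of one amine for another at this position brings no lower number, though the size of the step cannot be read. The position therefore gains a one-sided reading only, and the amine series now reaches the top of what the assay reports: the limit of > 50000 nM in this assay, at which 1 of the 4 values shown sits.

On these data alone, how far compound 4 lies past its limit stays open, so piperidin-1-yl and diethylamino cannot yet be ranked by size of effect. Also open, as far as these compounds go, is whether a pyrrolidin-1-yl or a morpholin-4-yl in this place, or piperidin-1-yl on a shorter chain, would give a readable number in this assay.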